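This account rests on a few compounds, and the source may have more. Where it says the series, first, only, none or still open, it means among the compounds named here.

Compound 1 `O=C1NCCN1c1ccc(S(=O)(=O)Nc2ccc(OC(F)F)cc2)cc1` is the starting point. In a functional assay on MCF7 cells (Homo sapiens) for antiproliferative activity, read by sulforhodamine B assay, with a stated time of 48 h (a lower number here means a stronger inhibitor, a higher number a weaker inhibitor), compound 1 gives 760 nM, which places it second highest among the three numbers measured. Compound 2 `COc1ccccc1NS(=O)(=O)c1ccc(N2CCNC2=O)cc1` gives 770 nM in this assay, a number within the scatter of that of compound 1, so the two cannot be ordered. Among the measured compounds shown here, compound 3 `COc1cccc(NS(=O)(=O)c2ccc(N3CCNC3=O)cc2)c1` gives 120 nM in this assay, the lowest number of the set; the only single-point step is a 6.4-fold lower number from compound 2 to compound 3 (0.81 log units; beyond the scatter), which moves the methoxy group on the aryl ring attached to the sulfonamide nitrogen and is beyond the scatter.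

Compound 4 `CCCCCCOc1ccc(NS(=O)(=O)c2ccc(N3CCNC3=O)cc2)cc1` is not yet measured. It differs from compound 1 in one place: hexyl in place of difluoromethyl on an oxygen on an aromatic ring. For the measured compounds named here, no measured step concerns the group on this oxygen; the step from compound 2 to compound 3 alters a different part of the molecule, so it gives no direct guidance here. With nothing to anchor the direction, the expectation for compound 4 is a number close to that of compound 1, with a wide range.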

Compound 4, half-maximal inhibitory concentration: > 1000 nM
Compound 4: no number, only a limit (the forecaster's own chance of this, stated with the estimate: 5%); middle value at least 1.5-fold (0.18 log units) from the limit.
By their numbers in this assay, from the lowest: compound 3; then compounds 1 and 2 (each within the scatter of the next). At a limit, above all of these: compound 4.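

In this assay compound 4 gives > 1000 nM, which is a limit and not a number: the limit of > 1000 nM in this assay, at which 1 of the 4 values shown sits. Among the compounds shown here, the step is an at least 1.3-fold higher number from compound 1 to compound 4 (0.11 log units; that floor lies within the scatter), and it is the first reading of any change to the group on this oxygen. It shows that hexyl in place of difluoromethyl brings no lower number at this position, although the floor of the step does not separate compound 4 from compound 1.

From the compounds shown here alone, how far compound 4 actually lies from compound 1 stays open, so the size of this change, and whether it exceeds the scatter at all, cannot be read. Also open, going by these compounds, is how this oxygen would read with a shorter chain such as methyl or ethyl, or with a hexyl chain ending in an amine or a carboxylic acid.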